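Selenocyanate carbamates: phenyl ester in place of fluorophenyl ester

The compounds below may be only part of what the source reports. "The series", "measured", "known", "first", "only" and "open" are said of these compounds alone.

Measured so far:
compound 1, `CCCCCCOC(=O)Nc1ccc([Se]C#N)cc1`, in a functional assay on HT-29 cells (Homo sapiens) for cytotoxicity, read by MTT assay, with a stated time of 72 h (on this read-out higher numbers stand for weaker inhibition of growth and lower numbers for stronger inhibition of growth), gives 40300 nM
compound 2, `N#C[Se]c1ccc(NC(=O)Oc2ccc(F)cc2)cc1`, in this assay gives 37600 nM

Compound 2 has the lower of the two numbers, but compound 1 sits only a hair above it, well within the scatter, so the two are not told apart. Both carbamates of the selenocyanate core thus land in the same range.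

Compound 3, `N#C[Se]c1ccc(NC(=O)Oc2ccccc2)cc1`, differs from compound 2 in one place: hydrogen in place of fluoro on an aromatic carbon. Among the compounds with values here, no measured pair with this change is available, so there is nothing to lean on beyond the two values above. The expectation is a step of no size beyond the scatter from compound 2 to compound 3, estimated as a 1.1-fold higher number from compound 2 to compound 3 (0.03 log units; within the scatter). For compound 3 in this assay the estimate is 40000 nM, with a range from 15000 nM to 110000 nM.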

Compound 3, concentration for total growth inhibition: 41700 nM
Compound 3: middle estimate off by 1.0-fold (0.02 log units), on the low side; measured number inside the range.
By their numbers in this assay, from the lowest: compounds 2, 1 and 3 (each within the scatter of the next).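

In this assay the swap of fluoro for hydrogen on this aromatic carbon, para to a large group, gives a 1.1-fold higher number from compound 2 to compound 3 (0.04 log units; within the scatter) and stays within the scatter, so the fluoro makes no readable difference at this position. Phenyl in place of hexyl on the oxygen next to a carbonyl group gives a 1.0-fold higher number from compound 1 to compound 3 (0.01 log units; within the scatter) and also stays within the scatter, so this aromatic ester and the hexyl ester are not told apart. No measurement at hand bears on why these changes leave the numbers together.

From the compounds shown here alone, whether an amine or a carboxylic acid on that aromatic carbon would move the number beyond the scatter remains open. So does the outcome for a longer chain in place of hexyl on the ester oxygen.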